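Rearranging a Four-Membered Ring Amine on a Shared Core

The source may report more compounds than this note shows. Statements on the series, on what has been measured and on what is new or still open speak of the compounds shown alone.

Going by the values given here, in a physicochemical assay for solubility, at pH 7.4 (on this read-out higher numbers stand for higher solubility and lower numbers for lower solubility), compound 2 `CNC1(C)CN(c2cc3c(cc2F)c(=O)c(C(=O)O)cn3C2CC2)C1` gives 0.7 ug/mL, which puts it at the low end of the numbers so far. Compound 3 `CNC1(C)CN(c2c(F)cc3c(=O)c(C(=O)O)cn(C4CC4)c3c2F)C1` gives 0.5 ug/mL, within the scatter of compound 2, while compound 1 `C[C@H]1[C@H](N)CN1c1nc2c(cc1F)c(=O)c(C(=O)O)cn2C1CC1` gives 20.3 ug/mL, well clear of both.

Compound 4 `CN[C@H]1CN(c2cc3c(cc2F)c(=O)c(C(=O)O)cn3C2CC2)[C@@H]1C` keeps the core of compound 2 and changes only the group on the aromatic carbon, ortho to a fluoro group: a group of 7 heavy atoms (5 carbon, 2 nitrogen; one four-membered non-aromatic ring with 1 hetero atom) in place of a group of 7 heavy atoms (5 carbon, 2 nitrogen; one four-membered non-aromatic ring with 1 hetero atom), on an aromatic carbon. The same atoms are joined differently, and the new group has 2 defined stereocentres.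

Among the compounds with values here, the only measured step, a 1.4-fold lower number from compound 2 to compound 3 (0.15 log units; within the scatter), is fluoro in place of hydrogen on an aromatic carbon. That is a different change, so it offers no direct guide. Compound 1 carries a group resembling the one entering, but on a different core, so its 20.3 ug/mL is only a loose pointer upward. A modest rise is therefore expected, with an estimated size of a 2.9-fold higher number from compound 2 to compound 4 (0.46 log units; beyond the scatter). For compound 4 the estimate is 2 ug/mL, with an expected range from 0.5 ug/mL to 10 ug/mL.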

Compound 4, solubility: 9.2 ug/mL
Estimate against measurement, compound 4: 4.6-fold (0.66 log units) below; measured number inside the range.
By their numbers in this assay, from the lowest: compounds 3 and 2 (each within the scatter of the next); then compound 4; then compound 1.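

Joining the same atoms differently, on the aromatic carbon ortho to a fluoro group, gives a 13-fold higher number from compound 2 to compound 4 (1.12 log units; beyond the scatter) in this assay. Going by these compounds alone, this shows that the number can shift strongly at this position even when the group keeps the same heavy atoms, hydrogen-bond donors and acceptors, whereas the one earlier step, a 1.4-fold lower number from compound 2 to compound 3 (0.15 log units; within the scatter), was a fluoro change elsewhere on the core. Nothing available explains the rise.

The compounds shown cannot separate the new arrangement of atoms from the two defined stereocentres of the entering group. As far as these compounds go, it remains open whether the mirror-image form of that group, or an ethyl group in place of its methyl on the ring, would give a number close to that of compound 4, and whether the same rise would appear on the core of compound 3.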